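A few compounds are considered here, and "the series" means these few. Any claim that something is new, unique, unknown or untested is made for them only; others in the source may bear on it.

Working notes on the succinimide-propanamide series.

Compound 1 `CC(C(=O)N1CCN(c2ccc(F)cc2)CC1)N1C(=O)CCC1=O` is the reference point. In a functional assay on the whole organism (strain Swiss) with Mus musculus as the target, in the maximal electroshock model, with a stated time of 0.25 h, at a dose of 300 mg/kg by the intraperitoneal route (a lower number here means a weaker effect, a higher number a stronger effect of the compound at the dose given), compound 1 gives 100%. Two neighbours are measured. Compound 2 `Cc1cccc(N2CCN(C(=O)C(C)N3C(=O)CCC3=O)CC2)c1` gives 100% in this assay, and the step of no change at the digits printed from compound 1 to compound 2 (within the scatter) is within the scatter. Compound 3 `CC(C(=O)N1CCN(c2ccccc2Cl)CC1)N1C(=O)CCC1=O` gives 0%, so the step of a number 100 percentage points lower from compound 1 to compound 3 (beyond the scatter) is large, as is a number 100 percentage points lower from compound 2 to compound 3 (beyond the scatter). Compound 1 therefore stands level with compound 2, the two together at the top of the three numbers, with compound 3 far below.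

Compound 4 `CCC(C(=O)N1CCN(c2ccc(F)cc2)CC1)N1C(=O)CCC1=O` is not yet measured. Its change from compound 1 is methyl in place of hydrogen on a saturated chain carbon, two bonds along the chain from an amide-type nitrogen in a ring and a carbonyl carbon. Among the measured compounds shown here, every measured step in this set alters the aryl group on the amine nitrogen in the ring; none of them touches the saturated chain carbon, so no measured step bears directly on this change. With compound 1 already at the top of what this assay reports, the expectation is an unchanged or slightly lower reading, and a drop of the size seen for compound 3 is not indicated by anything here.

The estimate for compound 4 in this assay is 90%, with a range from 50% to 100%. The expected step of a number 10 percentage points lower from compound 1 to compound 4 (within the scatter) is thus none beyond the scatter.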

Compound 4, a percentage reported as activity, at one dose (the size of the read-out at that dose, not a potency): 0%
Compound 4: middle estimate off by 90 percentage points, on the high side, and the stated range ends above it.
By their numbers in this assay, from the lowest: compounds 3 and 4 (each within the scatter of the next); then compounds 1 and 2 (each within the scatter of the next).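

In this assay, the saturated chain carbon two bonds along the chain from an amide-type nitrogen in a ring and a carbonyl carbon proves to be a sensitive position: methyl in place of hydrogen there gives a number 100 percentage points lower from compound 1 to compound 4 (beyond the scatter) and spans the whole distance between the highest and lowest readings in the set. The earlier steps shown here showed a large change in the reading only on altering the aryl group on the amine nitrogen in the ring, whereas here the 4-fluorophenyl group of compound 1 stays in place and a change of 1 heavy atom, read one bond further out as methyl to ethyl, is enough. Nothing shown here gives a reason for this loss.

The compounds shown leave open whether a longer chain such as propyl, or a hydroxymethyl group, at this carbon would behave as the ethyl group does, and whether the same change would have the same outcome with the 3-methylphenyl group of compound 2. With a reading at a single dose and a single stated time, they also leave open whether the effect of compound 4 is absent altogether or would appear under other conditions.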